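This account rests on a few compounds, and the source may have more. Where it says the series, first, only, none or still open, it means among the compounds named here.

Three compounds of this series share a core, and all three have been measured in a physicochemical assay for lipophilicity, measured as octanol-water partition; a higher number here means a more lipophilic compound, a lower number a more polar compound. Compound 1 `COc1cc(/C=N/NC(=O)COc2cccc3ccccc23)cc(OC)c1OC` carries a trimethoxy pattern on the aromatic ring attached to the imine, and in this assay compound 1 gives 3.26. Compound 2 `O=C(COc1cccc2ccccc12)N/N=C/c1c(O)ccc2ccccc12` bears a hydroxyl on a fused two-ring aromatic system; in this assay compound 2 gives 4.74. Compound 3 `O=C(COc1cccc2ccccc12)N/N=C/c1cccc([N+](=O)[O-])c1` carries a nitro group on a single six-membered aromatic ring, and in this assay compound 3 gives 3.97. That places compound 3 second highest of the three: compound 1 lies lower by a margin beyond the scatter, and compound 2 lies higher by a margin that is also beyond the scatter.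

Compound 4 `O=C(COc1cccc2ccccc12)N/N=C/c1cccc(Cl)c1` has not yet been measured in this assay. It differs from compound 3 in one place: chloro in place of nitro on an aromatic carbon. For the measured compounds named here, no measured pair in this set shows the effect of such a swap, so the expectation rests on the general behaviour of these two groups. The step from the nitro compound 3 to the chloro compound 4 is expected to be upward and beyond the scatter, roughly a number 0.88 log units higher from compound 3 to compound 4 (beyond the scatter). For compound 4 in this assay the estimate is therefore 4.85, with a likely range from 4.4 to 5.3.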

Compound 4, partition coefficient: 4.54
Compound 4: middle estimate off by 0.31 log units, on the high side; low and high end bracket the measured number.
By their numbers in this assay, from the lowest: compound 1; then compound 3; then compounds 4 and 2 (each within the scatter of the next).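

For the compounds shown here, compound 3 and compound 4 form the first pair here that differs in only one place, so the shared core drops out of the comparison and a single change can be read directly. In this assay, putting chloro in place of nitro on an aromatic carbon of the six-membered aromatic ring, meta to a large group, gives a number 0.57 log units higher from compound 3 to compound 4 (beyond the scatter). The swap exchanges a group of three heavy atoms and two hydrogen-bond acceptors for one of a single heavy atom and no acceptors, but no measurement shown gives a reason for the size or direction of the step.

Going by these compounds alone, with only one pair, it remains open whether the same swap would give a step of similar size at another place on the ring or on a different partner. Going by these compounds, it is also open how a methyl group, an amine or a carboxylic acid at this same place would compare with chloro and nitro, and so whether these two groups mark the ends of a wider range or sit close together within it.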